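Fluoro for Methyl on the Benzylamide of Compound 3

The source may hold more compounds than are shown below. What is called first, only, known or untested is meant among the compounds shown, and "the series" means these compounds.

Three thiazole amides and esters were compared in a functional assay on HCT-116 cells (Homo sapiens) for antiproliferative activity, read by MTT assay, with a stated time of 72 h; on this read-out higher numbers stand for weaker inhibition and lower numbers for stronger inhibition. Compound 1 `CCCC(=O)OC(C)c1nc([N+](=O)[O-])c(Sc2c(Cl)cncc2Cl)s1` gives 11700 nM, compound 2 `CC(=O)c1cc([N+](=O)[O-])c(Sc2ccc(F)cc2F)s1` gives 8820 nM, and compound 3 `Cc1ccc(CNC(=O)c2nc([N+](=O)[O-])c(Sc3c(Cl)cncc3Cl)s2)cc1` gives 6640 nM. Compound 3 carries the lowest of the three numbers, but its gaps to compound 2 and to compound 1 both fall within the usual scatter, so no ranking can be drawn from them. Compound 4 `O=C(NCc1ccc(F)cc1)c1nc([N+](=O)[O-])c(Sc2c(Cl)cncc2Cl)s1` differs from compound 3 in one place (fluoro in place of methyl on an aromatic carbon), para to a large group on the six-membered aromatic ring of carbon only. Within the data shown here, with no measured step of this kind among the three, the expected change in this assay from compound 3 to compound 4 is none beyond the scatter, a 1.1-fold lower number from compound 3 to compound 4 (0.04 log units; within the scatter). Compound 4 is therefore estimated at 6000 nM, within 2500 nM to 14000 nM.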

Compound 4, half-maximal inhibitory concentration: 11200 nM
Beside the measured number, compound 4's estimate is 1.9-fold (0.27 log units) below it, and the stated range covers the measured number.
By their numbers in this assay, from the lowest: compounds 3, 2, 4 and 1 (each within the scatter of the next).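

Among these compounds, the first step between compounds differing in one place in this assay is a 1.7-fold higher number from compound 3 to compound 4 (0.23 log units; within the scatter), so fluoro and methyl on this aromatic carbon cannot be told apart here. Among the compounds shown here, the earlier compounds held no such pair, so this position had no reading before, and this one change now gives a first reading that stays within the scatter. Nothing measured here offers a reason for this step. From the compounds shown here alone, whether methoxy, trifluoromethyl or a dimethylamino group at this position would move the number beyond the scatter remains open. So does how a plain benzyl amide, with hydrogen there, would read.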